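Chloro to Methoxy on the Aromatic Ring: An Expectation

The source may report more compounds than this note shows. Statements on the series, on what has been measured and on what is new or still open speak of the compounds shown alone.

Compound 2, `COc1ccc(C2CC(=NOC(=O)c3ccc(Cl)cc3)CC(c3ccc(OC)cc3)N2C)cc1`, belongs to a small set of three compounds that share one core and differ only in a single group on an aromatic ring. In a functional assay, with a stated time of 30 min (on this read-out higher numbers stand for weaker inhibition and lower numbers for stronger inhibition), compound 2 gives 135000 nM. Compound 1, `COc1ccc(C2CC(=NOC(=O)c3ccc(Br)cc3)CC(c3ccc(OC)cc3)N2C)cc1`, gives 121000 nM in this assay, and compound 3, `COc1ccc(C2CC(=NOC(=O)c3ccc([N+](=O)[O-])cc3)CC(c3ccc(OC)cc3)N2C)cc1`, gives 280000 nM. Its two neighbours frame compound 2: a 1.1-fold higher number from compound 1 to compound 2 (0.05 log units; within the scatter), a gap within the scatter, while a 2.1-fold higher number from compound 2 to compound 3 (0.32 log units; beyond the scatter), a modest gap beyond it. Compound 4, `COc1ccc(C(=O)ON=C2CC(c3ccc(OC)cc3)N(C)C(c3ccc(OC)cc3)C2)cc1`, has not yet been measured; it differs from compound 2 in one place: methoxy in place of chloro on an aromatic carbon. Going by the values given here, no measured step introduces a methoxy, so the only guides are the changes among bromo, chloro and nitro: a 2.3-fold higher number from compound 1 to compound 3 (0.36 log units; beyond the scatter) and a 2.1-fold higher number from compound 2 to compound 3 (0.32 log units; beyond the scatter), whereas a 1.1-fold higher number from compound 1 to compound 2 (0.05 log units; within the scatter). These show that swapping the group in this position shifts the number only modestly, if at all. For compound 4 a step of a 1.3-fold higher number from compound 2 to compound 4 (0.10 log units; within the scatter) is expected, within or only slightly beyond the scatter. Compound 4 is therefore estimated at 170000 nM, with a range from 70000 nM to 400000 nM.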

Compound 4, half-maximal inhibitory concentration: 68000 nM
Beside the measured number, compound 4's estimate is 2.5-fold (0.40 log units) above it; measured number below the stated range.
By their numbers in this assay, from the lowest: compounds 4, 1 and 2 (each within the scatter of the next); then compound 3.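

Methoxy on this aromatic carbon falls in with the two halogens, since its number stays within the scatter of both chloro (a 2.0-fold lower number from compound 2 to compound 4 (0.30 log units; within the scatter)) and bromo (a 1.8-fold lower number from compound 1 to compound 4 (0.25 log units; within the scatter)). Among these four compounds, nitro alone stands apart, and the widest step at this position is now the change from nitro to methoxy (a 4.1-fold lower number from compound 3 to compound 4 (0.61 log units; beyond the scatter)), so a group other than a halogen can sit here without any loss beyond the scatter. No measurement shown here accounts for why nitro differs from the other three groups.

On these data alone, it remains open whether an amine or a carboxylic acid in this place would stay close to compound 4 or move as far as compound 3. A longer chain, such as butoxy in place of methoxy, is equally untested among the compounds shown.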